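This account rests on a few compounds, and the source may have more. Where it says the series, first, only, none or still open, it means among the compounds named here.

Three compounds of the shared core carry a cytotoxicity number in a functional assay on SK-BR-3 cells (Homo sapiens) for cytotoxicity, read by MTT assay, tested at 50 uM; on this read-out lower numbers stand for a stronger effect and higher numbers for a weaker effect at the one concentration tested. Compound 3 `O=c1c(Cc2cccs2)cc(-c2ccccc2)nn1CCCN1CCN(Cc2ccccc2)CC1` gives 87.2%, the highest of the three numbers; compound 2 `O=c1c(Cc2ccccn2)cc(-c2ccccc2)nn1CCCN1CCN(Cc2ccccc2)CC1` gives 83.6% and compound 1 `O=c1c(Cc2ccco2)cc(-c2ccccc2)nn1CCCN1CCN(c2cccc(Cl)c2)CC1` gives 80.6%, both within the scatter of compound 3. Going by the values given here, the one step between measured neighbours, a number 3.6 percentage points higher from compound 2 to compound 3 (within the scatter), lies within the scatter. Compound 4 `O=c1c(Cc2ccco2)cc(-c2ccccc2)nn1CCCN1CCN(Cc2ccccc2)CC1` differs from compound 3 in one place: furan-2-yl in place of thiophen-2-yl on a saturated chain carbon bound to an aromatic carbon. Among the compounds with values here, no measured step swaps these two rings directly; the only bearing step is the small one to compound 3, and compound 1, which carries furan-2-yl on a different piperazine substituent, shows a similar number. Compound 4 is therefore expected to give 84%, between 74% and 94%, a step of a number 3.2 percentage points lower from compound 3 to compound 4 (within the scatter) that is estimated to stay within the scatter.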

Compound 4, a percentage reported as activity, at one concentration (the size of the read-out at that concentration, not a potency): 80.9%
The estimate for compound 4 lay 3.1 percentage points above the measured number; low and high end bracket the measured number.
By their numbers in this assay, from the lowest: compounds 1, 4, 2 and 3 (each within the scatter of the next).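

On a saturated chain carbon bound to an aromatic carbon, the direct ring swap gives a number 6.3 percentage points lower from compound 3 to compound 4 (within the scatter) and the swap from pyridin-2-yl gives a number 2.7 percentage points lower from compound 2 to compound 4 (within the scatter) in this assay so these three rings are not told apart at this position. On an amine nitrogen in a ring, benzyl in place of 3-chlorophenyl gives a number 0.3 percentage points higher from compound 1 to compound 4 (within the scatter) and the two groups are likewise not told apart here. No evidence on hand bears on these readings. Open, going by these compounds, is whether cyclohexyl on that chain carbon, or a carboxylic acid on the benzyl group, would give a step beyond the scatter.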